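Thiophene attachment point, from compound 2 to compound 3

The source may hold more compounds than are shown below. What is called first, only, known or untested is meant among the compounds shown, and "the series" means these compounds.

Measured so far:
compound 1 `Cc1cc(-c2nc3n(c2/C=N/NC(=N)N)CCS3)c(C)s1`: 41700 nM
compound 2 `N=C(N)N/N=C/c1c(-c2cccs2)nc2sccn12`: 28200 nM

In a functional assay on cells (Cancer cell lines, Homo sapiens) for inhibition (on this read-out higher numbers stand for weaker inhibition of growth and lower numbers for stronger inhibition of growth), compound 2 gives 28200 nM, the lower of the two numbers recorded so far. Compound 1 gives 41700 nM, which lies within the scatter of compound 2, so the two cannot be ordered. Among the measured compounds shown here, compound 1 and compound 2 differ in more than one place, and no single step between measured compounds exists in this assay.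

Compound 3 `N=C(N)N/N=C/c1c(-c2ccsc2)nc2sccn12` is compound 2 with thiophen-3-yl in place of thiophen-2-yl on an aromatic carbon. The same atoms are joined differently, and nothing leaves or enters the molecule beyond that.

For the measured compounds named here, with no measured step of this kind to lean on, the expectation rests on compound 2 alone, which gives 28200 nM. A step no larger than the scatter is expected in this assay, with no clear direction. Compound 3 is estimated at 30000 nM, with a range from 12000 nM to 80000 nM. The expected step of a 1.1-fold higher number from compound 2 to compound 3 (0.03 log units; within the scatter) stays inside the usual scatter.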

Compound 3, concentration for total growth inhibition: 31600 nM
Beside the measured number, compound 3's estimate is 1.1-fold (0.02 log units) below it, within the range that was stated.
By their numbers in this assay, from the lowest: compounds 2, 3 and 1 (each within the scatter of the next).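

In this assay, among the compounds shown here, the swap of thiophen-2-yl for thiophen-3-yl gives a 1.1-fold higher number from compound 2 to compound 3 (0.05 log units; within the scatter) and is the only step so far that differs in one place. On this aromatic carbon, next to the ring nitrogen, the attachment point of the thiophene therefore does not separate the two compounds on this read-out. Nothing available accounts for this result or bears on it.

On these data alone, it remains open whether a phenyl ring or a simple amine in place of the thiophene would give a step beyond the scatter. As far as these compounds go, it also remains open whether the same swap of attachment point would read alike on the core of compound 1.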